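The compounds below may be only part of what the source reports. "The series", "measured", "known", "first", "only" and "open" are said of these compounds alone.

Compound 3 `Nc1c(C(=O)N/N=C/c2ccccc2)oc2nc(-c3cccs3)cc(C(F)(F)F)c12` is examined in a functional assay on HepG2 cells (Homo sapiens) for antiproliferative activity, read by MTT assay (a lower number here means a stronger inhibitor, a higher number a weaker inhibitor), where compound 3 gives 9900 nM. Compound 1 `Nc1c(C(=O)N/N=C/c2ccc(Br)cc2)oc2nc(-c3cccs3)cc(C(F)(F)F)c12` gives 6100 nM, and compound 2 `Nc1c(C(=O)N/N=C/c2ccccc2)oc2nc(-c3ccccc3)cc(C(F)(F)F)c12` gives 13100 nM. Compound 3 thus sits second highest of the three numbers, and a 1.3-fold lower number from compound 2 to compound 3 (0.12 log units; within the scatter) shows how small the gap to its nearest neighbour is. Compound 4 `Nc1c(C(=O)N/N=C/c2ccc(Cl)cc2)oc2nc(-c3cccs3)cc(C(F)(F)F)c12` differs from compound 3 by chloro in place of hydrogen on an aromatic carbon. Within the data shown here, one measured step bears on this: a 1.6-fold higher number from compound 1 to compound 3 (0.21 log units; within the scatter), where taking a bromo away from that same place changed the number only within the scatter. Adding a chloro at that place is therefore expected to move the number little, if at all, giving a 1.4-fold lower number from compound 3 to compound 4 (0.15 log units; within the scatter). Compound 4 is estimated at 7000 nM, with a range from 3500 nM to 14000 nM.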

Compound 4, half-maximal inhibitory concentration: 8100 nM
The estimate for compound 4 lay 1.2-fold (0.06 log units) below the measured number, within the range that was stated.
By their numbers in this assay, from the lowest: compounds 1, 4, 3 and 2 (each within the scatter of the next, the first and the last beyond it).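

In this assay, swapping hydrogen for chloro gives a 1.2-fold lower number from compound 3 to compound 4 (0.09 log units; within the scatter), and swapping bromo for chloro gives a 1.3-fold higher number from compound 1 to compound 4 (0.12 log units; within the scatter). Hydrogen, chloro and bromo at this place on the six-membered aromatic ring therefore cannot be told apart by these numbers, so a second halogen adds to what bromo alone showed. Nothing available explains why these numbers lie so close together. Open, as far as these compounds go, is whether an amine or a carboxylic acid at this place would give a step beyond the scatter. Also open, from the compounds shown here alone, is whether chloro would behave the same with phenyl in place of thiophen-2-yl.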